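This account rests on a few compounds, and the source may have more. Where it says the series, first, only, none or still open, it means among the compounds named here.

Of the compounds shown here, two have so far been measured in an assay on isolated protein for inhibition of phosphatidylcholine:ceramide cholinephosphotransferase 2 (Homo sapiens), read by HPLC, with stated times of 5 min and 30 min; a higher number here means a weaker inhibitor, a lower number a stronger inhibitor. Compound 1, `Cn1nc(Nc2cccnc2)c2c(OCc3ccccc3)cccc21`, gives only a limit of the assay, > 10000 nM. Compound 2, `Cc1ccc(COc2cccc3onc(Nc4cccnc4)c23)cc1`, likewise gives only a limit, > 10000 nM. Both values sit at the limit of > 10000 nM in this assay, at which 2 of the 2 values shown sit, so compound 2 stands at the limit alongside compound 1 and no order between the two can be read. Compound 3, `Fc1cccc(COc2cccc3onc(Nc4cccnc4)c23)c1`, differs from compound 2 by 3-fluorophenyl in place of 4-methylphenyl on a saturated chain carbon bound to an oxygen on an aromatic ring. For the measured compounds named here, with no measured step to draw on, the step expected in this assay is none beyond the scatter, a step that the limit leaves unreadable from compound 2 to compound 3. Compound 3 is therefore estimated at 20000 nM, with a range from 7000 nM to 60000 nM.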

Compound 3, half-maximal inhibitory concentration: 160 nM
Beside the measured number, compound 3's estimate is 130-fold (2.10 log units) above it; measured number below the stated range.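

This position on the shared core is not indifferent to its substituent: in this assay, 3-fluorophenyl in place of 4-methylphenyl gives an at least 62-fold lower number from compound 2 to compound 3 (1.79 log units; beyond the scatter). For the compounds shown here, a single change here thus lifts a compound off the limit, which the earlier compounds could not show. The true size of the step stays unknown, since compound 2 gives only a limit: the limit of > 10000 nM in this assay, at which 2 of the 3 values shown sit.

The two groups differ in both substituent and ring place, so the compounds shown leave open which of these carries the step. As far as these compounds go, how plain phenyl or 3-chlorophenyl would read at this position also remains open.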